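A few compounds are considered here, and "the series" means these few. Any claim that something is new, unique, unknown or untested is made for them only; others in the source may bear on it.

Measured compounds:
- Compound 1, `CO[C@H]1O[C@H](CNC(=O)CN(C(C)=O)C2CCCCCC2)[C@@H](OS(=O)(=O)O)[C@H](OS(=O)(=O)O)[C@@H]1OS(=O)(=O)O`: in an assay on isolated protein for binding affinity to vascular endothelial growth factor A, long form (Homo sapiens), read by surface plasmon resonance (on this read-out lower numbers stand for tighter binding and higher numbers for weaker binding), compound 1 gives 3000000 nM.
- Compound 2, `CO[C@H]1O[C@H](CNC(=O)CN(C(C)=O)c2ccccc2)[C@@H](OS(=O)(=O)O)[C@H](OS(=O)(=O)O)[C@@H]1OS(=O)(=O)O`: in this assay compound 2 gives 76000 nM.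

Compound 2 stands with the lower of the two numbers; its nearest neighbour is compound 1, and the step from compound 1 to compound 2 was a 39-fold lower number from compound 1 to compound 2 (1.60 log units; beyond the scatter).

Compound 3, `CO[C@H]1O[C@H](CNC(=O)CN(C(C)=O)C2CCCCC2)[C@@H](OS(=O)(=O)O)[C@H](OS(=O)(=O)O)[C@@H]1OS(=O)(=O)O`, has not yet been measured. It differs from compound 2 in one place: cyclohexyl in place of phenyl on an amide-type nitrogen. Within the data shown here, only one measured step bears on this change, the step from compound 1 to compound 2, in which a seven-membered saturated ring gave way to a flat aromatic one and the number fell by a 39-fold lower number from compound 1 to compound 2 (1.60 log units; beyond the scatter). Compound 3 carries a six-membered saturated ring, which sits in between those two cases, so a step back toward weaker binding is expected in this assay, smaller than the measured one. The estimated step from compound 2 to compound 3 is a 6.6-fold higher number from compound 2 to compound 3 (0.82 log units; beyond the scatter). Compound 3 is therefore expected to give about 500000 nM, within a range from 150000 nM to 2000000 nM.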

Compound 3, dissociation constant: 1700000 nM
Estimate against measurement, compound 3: 3.4-fold (0.53 log units) below; the range from low to high includes it.
By their numbers in this assay, from the lowest: compound 2; then compounds 3 and 1 (each within the scatter of the next).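

Ring size alone does not settle the matter at this position: phenyl and cyclohexyl are both six-membered rings of carbon only, with the same count of heavy atoms, yet on the amide-type nitrogen the change gives a 22-fold higher number from compound 2 to compound 3 (1.35 log units; beyond the scatter). Between the two saturated rings, swapping cycloheptyl for cyclohexyl gives a 1.8-fold lower number from compound 1 to compound 3 (0.25 log units; within the scatter), so no effect of their ring size can be read here. Among these three compounds only the aromatic ring stands apart in this assay, and compound 2 shows the tightest binding of the set.

On these data alone, whether this holds for aromatic rings more widely stays open, as a pyridine ring, or a phenyl carrying a methoxy group, on the same nitrogen would show. Nothing shown gives a measured reason for the gap between the aromatic and the saturated rings.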